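The source may hold more compounds than are shown below. What is called first, only, known or untested is meant among the compounds shown, and "the series" means these compounds.

Compound 1 `COc1cc(/C=C/C(=O)c2ccc([N+](=O)[O-])cc2)cc(OC)c1`: 20000 nM
Compound 2 `C=CCOc1ccc(C(=O)/C=C/c2cc(OC)cc(OC)c2)cc1`: 25000 nM

In a functional assay (Homo sapiens) for inhibition (a lower number here means a stronger inhibitor, a higher number a weaker inhibitor), compound 2 gives 25000 nM and compound 1 gives 20000 nM, so the two stand level within the scatter. Compound 3 `C=CCOc1ccc(C(=O)/C=C/c2cc(OC)c(CCCCCC)c(OC)c2)cc1` carries hexyl in place of hydrogen on an aromatic carbon of compound 2: hexyl in place of hydrogen on an aromatic carbon. Going by the values given here, the only measured step, a 1.3-fold higher number from compound 1 to compound 2 (0.10 log units; within the scatter), swaps nitro for allyloxy at another place, and no measured step adds a hexyl group. The data therefore give no firm direction, and no change beyond the scatter is expected. The expected step is a 1.7-fold lower number from compound 2 to compound 3 (0.22 log units; within the scatter). For compound 3 the estimated value is 15000 nM, with an expected range of 3000 nM to 50000 nM.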

Compound 3, half-maximal inhibitory concentration: 15000 nM
Beside the measured number, compound 3's estimate shows no gap at the digits printed; measured number inside the range.
By their numbers in this assay, from the lowest: compounds 3, 1 and 2 (each within the scatter of the next).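

In this assay, hexyl in place of hydrogen on the aromatic carbon ortho to two methoxy groups gives a 1.7-fold lower number from compound 2 to compound 3 (0.22 log units; within the scatter). Going by these compounds alone, this is the first look at this position, and the hexyl chain leaves the number level with that of compound 2 rather than moving it beyond the scatter. No supporting evidence is available to explain this result. From the compounds shown here alone, whether an amine or a carboxylic acid at this position would shift the number remains open. So does the effect of a chain longer than hexyl.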